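A few compounds are considered here, and "the series" means these few. Any claim that something is new, unique, unknown or untested is made for them only; others in the source may bear on it.

Compound 1 `CC(=O)c1cc2ccc(OCCCn3cc(CNC(=O)CCCCC4CCSS4)nn3)cc2oc1=O` gives 38% in a functional assay on PC-12 cells (Rattus norvegicus) for cytotoxicity, read by MTT assay, with stated times of 3 h and 2 h, tested at 10 uM; on this read-out lower numbers stand for a weaker effect and higher numbers for a stronger effect at the one concentration tested.
Compound 2 `CCOC(=O)c1cc2ccc(OCCCn3cc(CNC(=O)CCCCC4CCSS4)nn3)cc2oc1=O` gives 36.1% in this assay.
Compound 3 `CC(=O)c1cc2ccc(OCCCCCn3cc(CNC(=O)CCCCC4CCSS4)nn3)cc2oc1=O` gives 20.8% in this assay.

Compound 2 differs from compound 1 by ethoxy in place of methyl on a carbonyl carbon, and that change made a step of a number 1.9 percentage points lower from compound 1 to compound 2 (within the scatter). Compound 3 stands lowest of the three, and its distance to compound 1 and to compound 2 lies beyond the scatter; how its core differs from the core of compound 1 is not broken down here.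

Compound 4 `CCOC(=O)c1cc2ccc(OCCCCCn3cc(CNC(=O)CCCCC4CCSS4)nn3)cc2oc1=O` has not been measured. It differs from compound 3 by ethoxy in place of methyl on a carbonyl carbon, the same change as from compound 1 to compound 2, at the same place. Because the earlier change gave a number 1.9 percentage points lower from compound 1 to compound 2 (within the scatter), the step from compound 3 to compound 4 is expected to be small, about a number 1.8 percentage points lower from compound 3 to compound 4 (within the scatter). Compound 4 is therefore estimated at 19%, between 8% and 32%.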

Compound 4, a percentage reported as activity, at one concentration (the size of the read-out at that concentration, not a potency): 38.3%
Compound 4: middle estimate off by 19.3 percentage points, on the low side, and the stated range ends below it.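

In this assay, ethoxy in place of methyl on a carbonyl carbon gave a number 17.5 percentage points higher from compound 3 to compound 4 (beyond the scatter), and this step does not match the earlier one: the same change on two cores in this assay, a number 1.9 percentage points lower (within the scatter) from compound 1 to compound 2 and a number 17.5 percentage points higher (beyond the scatter) from compound 3 to compound 4, 19.4 percentage points apart, beyond the scatter of two such steps. In this series, then, the size of the step changes with the core that carries it, and a step read on the core of compound 1 cannot simply be carried over to the core of compound 3. The two pairs do not show why the steps differ, and they give no rule for any other core.

The compounds shown leave open what a carboxylic acid would give on that carbonyl carbon. They also leave open how the same change would behave on a core with a longer chain than that of compound 3.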